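Methoxy for hydrogen on an aromatic carbon: growth-inhibition notes

The source may hold more compounds than are shown below. What is called first, only, known or untested is meant among the compounds shown, and "the series" means these compounds.

Measured in a functional assay on HepG2 cells (Homo sapiens) for antiproliferative activity, read by MTT assay, with a stated time of 48 h; on this read-out lower numbers stand for stronger inhibition of growth and higher numbers for weaker inhibition of growth:
Compound 1 `CCCOC(=O)N1N=C(c2ccccc2)CC1c1cc(OC)c(OC)c(OC)c1` gives > 10000 nM, a limit of the assay.
Compound 2 `CCCOC(=O)N1N=C(c2ccc(OC)cc2)CC1c1cc(OC)c(OC)c(OC)c1` gives > 10000 nM, also a limit of the assay.
Within the data shown here, compound 3 `COC(=O)N1N=C(c2ccccc2)CC1c1ccc(OC)cc1` gives 12000 nM, the only number in the set.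

Compound 2 differs from compound 1 by methoxy in place of hydrogen on an aromatic carbon. The step that the two limits leave unreadable from compound 1 to compound 2; both compounds sit at the limit of > 10000 nM in this assay, at which 2 of the 3 values shown sit. The difference between the core of compound 1 and that of compound 3 is not broken down here.

Compound 4 `COC(=O)N1N=C(c2ccccc2)CC1c1ccc(OC)c(OC)c1` differs from compound 3 by methoxy in place of hydrogen on an aromatic carbon. This is the same kind of change as that from compound 1 to compound 2, but the place differs: here the entering group sits ortho to a methoxy group and meta to a large group, there para to a large group. The earlier step, being unreadable, gives no direction. The step of a 1.2-fold lower number from compound 3 to compound 4 (0.08 log units; within the scatter) is expected to stay within scatter, resting on compound 3 at 12000 nM in this assay. Compound 4 is therefore estimated at 10000 nM, spanning 3000 nM to 30000 nM, with a fair chance that only a limit is reported.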

Compound 4, concentration for 50% growth inhibition: 9150 nM
For compound 4 the middle estimate is 1.1-fold (0.04 log units) above the measured one; the range from low to high includes it.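

In this assay, methoxy in place of hydrogen on an aromatic carbon gives a 1.3-fold lower number from compound 3 to compound 4 (0.12 log units; within the scatter), so on this core the change does not separate the two compounds. The same kind of change on the core of compound 1 cannot be read, with both compounds of that pair at a limit of the assay: the limit of > 10000 nM in this assay, at which 2 of the 4 values shown sit. One readable step, with the entering group at a different place, therefore shows neither that the result carries from one core to the other nor that it fails to.

Open, on these data alone, is whether an amine or a carboxylic acid at this place would move the number beyond the scatter. Also open, as far as these compounds go, is whether a longer chain in place of methoxy would do so.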